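Swapping a chlorophenyl for a cyanophenyl on the imine

This account rests on a few compounds, and the source may have more. Where it says the series, first, only, none or still open, it means among the compounds named here.

Measured compounds:
- compound 1, `O=C(NNc1ccnc2cc(Cl)ccc12)c1ccccc1/N=C/c1ccccc1Cl`: 5.5
- compound 2, `O=C(NNc1ccnc2cc(Cl)ccc12)c1ccccc1/N=C/c1ccc(Cl)cc1Cl`: 6.22
- compound 3, `Cc1ccc(/C=N/c2ccccc2C(=O)NNc2ccnc3cc(Cl)ccc23)cc1`: 5.31

All three share one core and differ only in the aryl group on the carbon with a double bond to nitrogen. In a physicochemical assay for lipophilicity, measured as octanol-water partition (on this read-out lower numbers stand for lower lipophilicity and higher numbers for higher lipophilicity), compound 1 stands second highest of the three, close to compound 3 and clearly under compound 2. The measured steps show what the aryl group does: a number 0.72 log units higher from compound 1 to compound 2 (beyond the scatter), a number 0.19 log units lower from compound 1 to compound 3 (within the scatter) and a number 0.91 log units lower from compound 2 to compound 3 (beyond the scatter). In short, adding a chlorine to the aryl raised the number by a modest amount, while exchanging 2-chlorophenyl for 4-methylphenyl stayed within the scatter.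

Compound 4, `N#Cc1ccc(/C=N/c2ccccc2C(=O)NNc2ccnc3cc(Cl)ccc23)cc1`, has not yet been measured in this assay. Its change from compound 1 is 4-cyanophenyl in place of 2-chlorophenyl on a carbon with a double bond to nitrogen. The entering group carries a nitrile and one hydrogen-bond acceptor, where the leaving group carried a chlorine and none. Within the data shown here, the step from compound 1 to compound 2 shows how much one chlorine adds; here a chlorine leaves and a nitrile enters, and no measured step covers a nitrile. Compound 4 is therefore expected to come out lower than compound 1, by a step of about a number 0.90 log units lower from compound 1 to compound 4 (beyond the scatter), and the estimate for compound 4 is 4.6, with a range from 4.1 to 5.1.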

Compound 4, partition coefficient: 4.83
Compound 4: the middle estimate sits 0.23 log units below what was measured; measured number inside the range.
By their numbers in this assay, from the lowest: compound 4; then compounds 3 and 1 (each within the scatter of the next); then compound 2.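

Among these compounds, until now, the steps at this aryl group had either raised the number, as the added chlorine did, or stayed within the scatter, and no compound sat clearly under compound 1. In this assay, the nitrile supplies that missing downward move, with a number 0.67 log units lower from compound 1 to compound 4 (beyond the scatter) and, in the smallest change of the set, where cyano takes the place of methyl on an aromatic carbon, a number 0.48 log units lower from compound 3 to compound 4 (beyond the scatter). The spread at this single position now reaches a number 1.39 log units lower from compound 2 to compound 4 (beyond the scatter), a large step, although nothing available explains why the number moves this way.

The step from compound 1 to compound 4 changes both the group and where it sits on the ring, so a 4-chlorophenyl analogue would be needed to set chlorine against the nitrile with only one thing differing. As far as these compounds go, how an amine or a carboxylic acid on the same ring would compare with the nitrile, and whether either would extend the spread further down, also remains open.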